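Replacing Amino with Nitro on Compound 2

The source may report more compounds than this note shows. Statements on the series, on what has been measured and on what is new or still open speak of the compounds shown alone.

In a functional assay on HT-29 cells (Homo sapiens) for inhibition, read by MTT assay (a higher number here means a weaker inhibitor, a lower number a stronger inhibitor), compound 1 `COc1ccc2c(c1)CC[C@@H](O)/C2=C/c1cc(OC)c(OC)c(OC)c1` gives 900 nM and compound 2 `COc1ccc(/C=C2\c3cc(OC)c(OC)c(OC)c3CC[C@@H]2O)cc1N` gives 160 nM as its half-maximal inhibitory concentration. Compound 2 therefore holds the lower of the two numbers, and the gap between them lies beyond the usual scatter. With only these two compounds measured, however, nothing can be said about a wider trend.

Compound 3 `COc1ccc(/C=C2\c3cc(OC)c(OC)c(OC)c3CC[C@@H]2O)cc1[N+](=O)[O-]` has nitro in place of amino on an aromatic carbon, ortho to a methoxy group, and the full count of that change reads nitro in place of amino on an aromatic carbon for this pair. Going by the values given here, no measured pair shows this swap on its own, so its size in this assay cannot be read from the data and remains a judgement with wide margins. A moderate loss of inhibition is expected rather than a gain, probably somewhat beyond the scatter. The estimated change is a 3.1-fold higher number from compound 2 to compound 3 (0.49 log units; beyond the scatter) on this expectation, with a higher number as its direction. For compound 3 the estimated value is 500 nM with an expected range from 130 nM to 2000 nM in this measurement.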

Compound 3, half-maximal inhibitory concentration: 1590 nM
The estimate for compound 3 lay 3.2-fold (0.50 log units) below the measured number; the measured number falls inside the stated range.
By their numbers in this assay, from the lowest: compound 2; then compounds 1 and 3 (each within the scatter of the next).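

In this assay, putting nitro in place of amino on this aromatic carbon, ortho to a methoxy group, gives a 9.9-fold higher number from compound 2 to compound 3 (1.00 log units; beyond the scatter) and so shows that the group held at this position matters to the read-out. Going by these compounds alone, this is the first single change that can be read directly on the shared core, as compound 1 and compound 2 differ in more than one place and offered no such step. The change removes the one hydrogen-bond donor that amino carries here and adds heavy atoms, but nothing available ties the size of the step to either of these differences or to any other cause.

The two groups shown cannot tell whether a hydroxyl, an acetamide or a dimethylamino group on this carbon would give a number nearer that of compound 2 or that of compound 3. From the compounds shown here alone, whether the swap from amino to nitro would give a step of similar size and the same direction on another core, or in any other assay, also remains open.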